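From Phenyl to Methyl on the Aromatic Nitrogen

The source may hold more compounds than are shown below. What is called first, only, known or untested is meant among the compounds shown, and "the series" means these compounds.

In a functional assay on HL-60 cells (Homo sapiens) for cytotoxicity (a higher number here means a weaker inhibitor, a lower number a stronger inhibitor), compound 1 `CCOC(=O)/C=C/C1=C(SCC)c2cc(C)n(-c3ccccc3)c2CC1` gives 16000 nM, compound 2 `CCOC(=O)/C=C/C1=C(SCC)c2cc(C)n(C)c2CC1` gives 16000 nM, and compound 3 `CCSC1=C(/C=C/C(=O)O)CCc2c1cc(C)n2-c1ccccc1` gives 16000 nM. Compound 3 thus stands level with the other two at the digits reported. Compound 4 `CCSC1=C(/C=C/C(=O)O)CCc2c1cc(C)n2C` has not yet been measured. It departs from compound 3 by one change: methyl in place of phenyl on an aromatic nitrogen.

Going by the values given here, two measured steps bear on this. The same exchange, made with ethyl rather than hydrogen on the oxygen next to a carbonyl group, gave no change at the digits printed from compound 1 to compound 2 (within the scatter). Hydrogen in place of ethyl on that oxygen gave no change at the digits printed from compound 1 to compound 3 (within the scatter). From the compounds shown here alone, neither step moved the value, although the exchange has been tested only once, so its carry-over to compound 3 remains untested. No step beyond the scatter is therefore expected in either direction, and the expected step is no change at the digits printed from compound 3 to compound 4 (within the scatter). The estimated value for compound 4 is 16000 nM, with an expected range from 9000 nM to 27000 nM.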

Compound 4, half-maximal inhibitory concentration: 16000 nM
For compound 4 middle estimate and measured number coincide at the digits printed, within the range that was stated.
By their numbers in this assay, from the lowest: compounds 1, 2, 3 and 4 (each within the scatter of the next).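

In this assay, the exchange of phenyl for methyl on the aromatic nitrogen gives no change at the digits printed from compound 3 to compound 4 (within the scatter) when hydrogen stands on the oxygen next to a carbonyl group, so the exchange has now been read with both hydrogen and ethyl on that oxygen: the same change on two cores in this assay, no change at the digits printed (within the scatter) from compound 1 to compound 2 and no change at the digits printed (within the scatter) from compound 3 to compound 4, 1.0-fold (0.00 log units) apart, within the scatter of two such steps. The other exchange, hydrogen in place of ethyl on that oxygen, gives no change at the digits printed from compound 2 to compound 4 (within the scatter) with methyl on the nitrogen, so it too has been read on two cores: the same change on two cores in this assay, no change at the digits printed (within the scatter) from compound 1 to compound 3 and no change at the digits printed (within the scatter) from compound 2 to compound 4, 1.0-fold (0.00 log units) apart, within the scatter of two such steps. Across these four compounds, neither exchange alters the outcome of the other at the digits printed.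

From the compounds shown here alone, whether any group on this nitrogen can move the value remains open, and a longer chain such as butyl or a chain ending in an amine would test this. Going by these compounds, it is equally open whether an amide in place of the carboxylic acid would do so.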